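Amide-side changes and cytotoxicity in one series

A few compounds are considered here, and "the series" means these few. Any claim that something is new, unique, unknown or untested is made for them only; others in the source may bear on it.

Of the compounds shown here, three sharing one core have been measured in an ADME assay on L6 cells (Rattus norvegicus) for cytotoxicity; on this read-out higher numbers stand for weaker inhibition and lower numbers for stronger inhibition. Compound 1 `O=C(CCCc1c[nH]c2ccccc12)NCCCN1CCN(CCCNc2ccnc3cc(Cl)ccc23)CC1` gives 6500 nM. Compound 2 `O=C(CCCOc1ccccc1)NCCCN1CCN(CCCNc2ccnc3cc(Cl)ccc23)CC1` gives 9300 nM, and compound 3 `COc1cccc(C(=O)NCCCN2CCN(CCCNc3ccnc4cc(Cl)ccc34)CC2)c1` gives 9300 nM. The three numbers sit close together: a 1.4-fold higher number from compound 1 to compound 2 (0.16 log units; within the scatter), a 1.4-fold higher number from compound 1 to compound 3 (0.16 log units; within the scatter), and no change at the digits printed from compound 2 to compound 3 (within the scatter). Compound 1 thus gives the number from which neither other compound is separated beyond the scatter.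

Compound 4 `O=C(NCCCN1CCN(CCCNc2ccnc3cc(Cl)ccc23)CC1)c1ccc(Cl)c([N+](=O)[O-])c1` is not yet measured. It differs from compound 1 in one place: 4-chloro-3-nitrophenyl in place of 3-(1H-indol-3-yl)propyl on a carbonyl carbon. The step that bears most on this one also put an aromatic group, 3-methoxyphenyl, on the carbonyl carbon in place of 3-(1H-indol-3-yl)propyl, and was a 1.4-fold higher number from compound 1 to compound 3 (0.16 log units; within the scatter); the further exchange of carbonyl substituents gave no change at the digits printed from compound 2 to compound 3 (within the scatter). Within the data shown here, no measured step involves a chlorine or a nitro group on this ring, so nothing speaks for a larger move. For compound 4 the expected step is a 1.2-fold higher number from compound 1 to compound 4 (0.09 log units; within the scatter), which is to say no change beyond the scatter. Compound 4 is therefore estimated at 8000 nM, with a range from 3000 nM to 20000 nM.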

Compound 4, half-maximal inhibitory concentration: 11300 nM
For compound 4 the middle estimate is 1.4-fold (0.15 log units) below the measured one, within the range that was stated.
By their numbers in this assay, from the lowest: compounds 1, 2, 3 and 4 (each within the scatter of the next).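

Notes on the carbonyl substituent in this assay: 4-chloro-3-nitrophenyl brings a chlorine and a nitro group into the series, and compound 4 stays within the scatter of all three earlier compounds (a 1.7-fold higher number from compound 1 to compound 4 (0.24 log units; within the scatter); a 1.2-fold higher number from compound 3 to compound 4 (0.08 log units; within the scatter); a 1.2-fold higher number from compound 2 to compound 4 (0.08 log units; within the scatter)). Among these compounds, this position on the carbonyl carbon has now carried 3-(1H-indol-3-yl)propyl, 3-phenoxypropyl, 3-methoxyphenyl and 4-chloro-3-nitrophenyl, and no step among the four compounds lies beyond the scatter. No supporting data bear on why these numbers sit so close together.

Still open, from the compounds shown here alone, is whether an amine or a carboxylic acid on the aromatic ring, or a longer chain between that ring and the carbonyl carbon, would give a step beyond the scatter. Also open, going by these compounds, is whether changes to the shared core would move the number more than changes at this position.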